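Aryl amide series: swapping thiophene for pyrazole

The source may report more compounds than this note shows. Statements on the series, on what has been measured and on what is new or still open speak of the compounds shown alone.

Two compounds from this series share a common core and differ only in the ring attached to the aromatic carbon para to the large amide group. Compound 1 `CN1CCCc2ccc(NC(=O)c3ccc(-c4ccccc4)cc3)cc21` carries a phenyl there and gives 7.5 in a functional assay for antagonist activity at transient receptor potential cation channel subfamily V member 1 (Homo sapiens), read by FLIPR and calcium flux; a higher number here means a more potent compound, by a factor of ten per unit of this negative logarithm, a lower number a less potent compound. Compound 2 `CN1CCCc2ccc(NC(=O)c3ccc(-c4ccsc4)cc3)cc21` carries a thiophen-3-yl and gives 7.8 in this assay. The move a number 0.30 log units higher from compound 1 to compound 2 (within the scatter) is within the scatter, so the two values cannot be ordered with confidence. Compound 2 nonetheless holds the higher of the two numbers shown, with compound 1 as its only neighbour.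

Compound 3 `CN1CCCc2ccc(NC(=O)c3ccc(-n4cccn4)cc3)cc21` takes the next step: 1H-pyrazol-1-yl in place of thiophen-3-yl on an aromatic carbon. Going by the values given here, the only measured step that bears on this position is the one from compound 1 to compound 2, and it was within the scatter. That step exchanged one aromatic ring for another of the same size; the present step also keeps the size but brings in a ring with a second hetero atom and one more acceptor. Compound 3 is therefore expected to land close to compound 2, with a step of a number 0.40 log units lower from compound 2 to compound 3 (beyond the scatter) near the edge of the scatter and, if anything, downward. The estimate for compound 3 in this assay is 7.4, with a range from 6.7 to 8.1.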

Compound 3, negative logarithm of the antagonist equilibrium constant: 6.9
Beside the measured number, compound 3's estimate is 0.50 log units above it; measured number inside the range.
By their numbers in this assay, from the lowest: compound 3; then compounds 1 and 2 (each within the scatter of the next).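

Going by these compounds alone, this is the first step at this position to clear the scatter in this assay: with 1H-pyrazol-1-yl in place of thiophen-3-yl, the result is a number 0.90 log units lower from compound 2 to compound 3 (beyond the scatter), although both rings are five-membered and aromatic and both have the same count of heavy atoms. The comparison with the six-membered ring points the same way, with 1H-pyrazol-1-yl in place of phenyl giving a number 0.60 log units lower from compound 1 to compound 3 (beyond the scatter), so the position does not accept every aromatic ring alike, even though compounds 1 and 2 could not be told apart. No measurement is available that accounts for this loss.

The exchange of thiophen-3-yl for 1H-pyrazol-1-yl changes several things at once, replacing sulfur with two nitrogens and raising the count of hydrogen-bond acceptors, and these three compounds cannot show which of those differences matters. From the compounds shown here alone, whether the loss belongs to this particular ring or extends to other rings with nitrogen stays open, and a furan-3-yl, a 1H-pyrazol-4-yl or a pyridin-3-yl at this place would bear on that question.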